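The source may hold more compounds than are shown below. What is called first, only, known or untested is meant among the compounds shown, and "the series" means these compounds.

Compound 1 `COc1ccc(-c2noc(-c3ccccc3)n2)cc1OC1CCCC1` stands at the edge of what a functional assay on HCT-116 cells (Homo sapiens) for antiproliferative activity, read by MTT assay, with a stated time of 24 h (on this read-out lower numbers stand for stronger inhibition and higher numbers for weaker inhibition), can report: compound 1 gives > 1000000 nM, which is a limit of the assay and not a number. Compound 2 `COc1cc(-c2noc(-c3ccncc3)n2)ccc1OCc1ccccc1` likewise gives only a limit in this assay, > 1000000 nM. Going by the values given here, both values shown therefore sit at the limit of > 1000000 nM in this assay, at which 2 of the 2 values shown sit, and no measured step between compounds exists in this set. Compound 3 `COc1ccc(-c2noc(C3CCNCC3)n2)cc1OC1CCCC1` carries piperidin-4-yl in place of phenyl on an aromatic carbon. With compound 1 at a limit, the expected step from compound 1 to compound 3 is an at least 2.0-fold lower number from compound 1 to compound 3 (0.30 log units; that floor lies within the scatter), with the direction uncertain. Compound 3 is estimated at 500000 nM, within 30000 nM to 1500000 nM, and may again be reported only as a limit.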

Compound 3, half-maximal inhibitory concentration: 1540 nM
Beside the measured number, compound 3's estimate is 320-fold (2.51 log units) above it; the measured number lies below the stated range.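

At this aromatic carbon the phenyl-to-piperidin-4-yl exchange gives an at least 640-fold lower number from compound 1 to compound 3 (2.81 log units; beyond the scatter), so the position is sensitive to the group it carries in this assay. The size of this step is a floor, as compound 1 gives > 1000000 nM, a limit and not a number. Compound 3 is the only compound shown with a value off the limit: the limit of > 1000000 nM in this assay, at which 2 of the 3 values shown sit.

Open, going by these compounds, is whether the ring nitrogen of piperidin-4-yl or the non-aromatic ring itself accounts for the step. Cyclohexyl would separate these two, and an open-chain amine such as aminoethyl would test whether the ring is needed at all.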